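This account rests on a few compounds, and the source may have more. Where it says the series, first, only, none or still open, it means among the compounds named here.

For the measured compounds named here, in a functional assay on LoVo cells (Homo sapiens) for cytotoxicity, read by colorimetric assay and MTT assay (a higher number here means a weaker inhibitor, a lower number a stronger inhibitor), compound 1 `CCN(CC)C(=O)Cn1c(=O)c(-c2ccc(OC)cc2)cc2c(OC)cc(OC)cc21` gives 10000 nM and compound 2 `COc1ccc(-c2cc3c(OC)cc(OC)cc3n(CC(=O)OCc3ccccc3)c2=O)cc1` gives 10000 nM, so compound 2 stands level with compound 1, its only measured neighbour. Compound 3 `COC(=O)CCn1c(=O)c(-c2ccc(OC)cc2)cc2c(OC)cc(OC)cc21` has not yet been measured. The change from compound 2 is (methoxycarbonyl)methyl in place of benzyloxycarbonyl on a saturated chain carbon bound to an aromatic nitrogen. In short, it is (methoxycarbonyl)methyl in place of benzyloxycarbonyl on a saturated chain carbon bound to an aromatic nitrogen. Going by the values given here, one measured step bears on this, no change at the digits printed from compound 1 to compound 2 (within the scatter), and it stayed within the scatter. Among the compounds with values here, this is thin evidence, since it rests on two compounds and no measured step shows what losing the ring does. Within the data shown here, with only the step of no change at the digits printed from compound 1 to compound 2 (within the scatter) as a guide, no change beyond the scatter is expected in this assay. The estimated step is no change at the digits printed from compound 2 to compound 3 (within the scatter). Compound 3 is expected at 10000 nM, with an estimated range from 4000 nM to 20000 nM.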

Compound 3, half-maximal inhibitory concentration: 10000 nM
Compound 3: middle estimate and measured number agree at the digits printed, within the range that was stated.
By their numbers in this assay, from the lowest: compounds 1, 2 and 3 (each within the scatter of the next).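

The new compound removes something the first pair could not test: benzyloxycarbonyl carries a six-membered aromatic ring of carbon only, while (methoxycarbonyl)methyl has no ring and fewer heavy atoms, yet this assay shows no change at the digits printed from compound 2 to compound 3 (within the scatter) for this exchange. Replacing the diethylcarbamoyl group gives the same picture, with no change at the digits printed from compound 1 to compound 3 (within the scatter) in this comparison. At this place on the shared core, then, an amide, a benzyl ester and a shorter methyl ester on the chain all read alike, and nothing available explains this lack of difference.

Going by these compounds, whether a carboxylic acid or an amine at the end of the chain would separate from these three compounds remains open. So does the effect of a longer chain at this place.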